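A Ring Hydroxy Added to a Thymine Nucleoside Analogue

The source may report more compounds than this note shows. Statements on the series, on what has been measured and on what is new or still open speak of the compounds shown alone.

Measured compounds:
compound 1, `Cc1cn([C@@H]2O[C@H](CO)[C@@H](CN)[C@@H]2O)c(=O)[nH]c1=O`: > 100 uM
compound 2, `Cc1cn([C@H]2C[C@H](CF)[C@@H](CO)O2)c(=O)[nH]c1=O`: > 100 uM
compound 3, `Cc1cn([C@H]2C[C@H](CO)[C@@H](CO)O2)c(=O)[nH]c1=O`: 1 uM

Three compounds were tested in a functional assay on CCRF-CEM cells (Homo sapiens) for antiproliferative activity, with a stated time of 72 h; on this read-out higher numbers stand for an effect only at larger amounts of compound and lower numbers for an effect already at smaller amounts. For compound 1 the value of > 100 uM is a limit of the assay, not a number. For compound 2 the value of > 100 uM is likewise a limit. For the measured compounds named here, compound 3 gives 1 uM and is the only compound with a number; the other two sit at the limit of > 100 uM in this assay, at which 2 of the 3 values shown sit. Going by the values given here, the single measured step, an at least 100-fold lower number from compound 2 to compound 3 (2.00 log units; beyond the scatter), is large.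

Compound 4, `Cc1cn([C@@H]2O[C@H](CO)[C@@H](CO)[C@@H]2O)c(=O)[nH]c1=O`, has not been measured in this assay. It differs from compound 3 by hydroxy in place of hydrogen on a saturated ring carbon. Among the compounds with values here, no measured step concerns a hydroxy entering a ring carbon, so the measured step from compound 2 to compound 3 does not bear on it directly; it only shows how strongly the numbers can move with a small change. With no direct guide, compound 4 is estimated at 10 uM, in the range 1 uM to 100 uM, which would mean an expected step of a 10-fold higher number from compound 3 to compound 4 (1.00 log units; beyond the scatter).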

Compound 4, concentration for half-maximal effect: > 100 uM
Compound 4 ended at the assay's limit; the forecaster's own chance of this, stated with the estimate: 30%; at least 10-fold (1.00 log units) between middle value and limit.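

Replacing a hydrogen with a hydroxy on the saturated ring carbon gives, in this assay, an at least 100-fold higher number from compound 3 to compound 4 (2.00 log units; beyond the scatter), so the number responds to this ring position as well as to the chain carbon that the earlier compounds had shown changing. Compound 4 gives > 100 uM, which is a limit of the assay and not a number. Compound 3 therefore keeps the only number in the set, and a single change at either of these two places, on the ring carbon in compound 4 or on the chain carbon in compound 2, ends at the limit: the limit of > 100 uM in this assay, at which 3 of the 4 values shown sit.

From the compounds shown here alone, compound 1 and compound 4 both sit at limits, so the step between them cannot be read, and how far either lies past the limit stays unknown. Going by these compounds, whether an amine or a methoxy group on that ring carbon would return a measurable number also stays open.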